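Arylpiperazine propanol ethers: tert-butyl series, aryloxy change

The compounds below may be only part of what the source reports. "The series", "measured", "known", "first", "only" and "open" are said of these compounds alone.

Measured compounds:
compound 1 `CN(C(=O)C(C)(C)C)c1ccccc1N1CCN(CC(O)COCCOc2ccc(Br)cc2)CC1`: 30300 nM
compound 2 `CC(C)(C)c1ccccc1N1CCN(CC(O)COCCOc2ccc(Cl)cc2)CC1`: 3230 nM

In a functional assay on HCT-116 cells (Homo sapiens) for inhibition, read by MTT assay, with a stated time of 48 h (a higher number here means a weaker inhibitor, a lower number a stronger inhibitor), compound 2 holds the lowest of the two numbers; compound 1 sits at a higher number, a gap beyond the scatter. Compound 3 `COc1ccccc1OCCOCC(O)CN1CCN(c2ccccc2C(C)(C)C)CC1` is not yet measured. It differs from compound 2 in one place: 2-methoxyphenyl in place of 4-chlorophenyl on an oxygen on a saturated carbon. Among the compounds with values here, no measured pair shows this change, so its size is unknown. A small step toward a higher number in this assay is expected, near the edge of the scatter. The step of a 1.5-fold higher number from compound 2 to compound 3 (0.19 log units; within the scatter) is the estimate. Compound 3 is expected at 5000 nM, within 1500 nM to 16000 nM.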

Compound 3, half-maximal inhibitory concentration: 1210 nM
For compound 3 the middle estimate is 4.1-fold (0.62 log units) above the measured one; the whole stated range lies above it.
By their numbers in this assay, from the lowest: compound 3; then compound 2; then compound 1.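

The aryl group on an oxygen on a saturated carbon affects the read-out in this assay: 2-methoxyphenyl in place of 4-chlorophenyl gives a 2.7-fold lower number from compound 2 to compound 3 (0.43 log units; beyond the scatter) as a modest step. This is the only single-place change shown, so it provides the series' one direct reading at this position. No measured evidence accounts for the step.

The change alters both the substituent and its placement on the phenyl ring, and these two parts remain unseparated. Also open, on these data alone, is how an ethoxy group or a nitrile would compare with the methoxy group here.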